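Series notes: naphthyl regioisomer at the chain carbon

This account rests on a few compounds, and the source may have more. Where it says the series, first, only, none or still open, it means among the compounds named here.

Values in an assay on isolated protein for inhibition of protein deacetylase HDAC6 (Homo sapiens), read by fluorescence, with stated times of 10 min and 2 h; on this read-out lower numbers stand for stronger inhibition and higher numbers for weaker inhibition:
compound 1 `CC1(c2ccccc2)NC(=O)N(Cc2ccc(C(=O)NO)cc2)C1=O` gives 74.9 nM
compound 2 `O=C(NO)c1ccc(CN2C(=O)NC(Cc3ccc(Cl)cc3)(c3ccccc3)C2=O)cc1` gives 54 nM
compound 3 `O=C(NO)c1ccc(CN2C(=O)NC(Cc3cccc4ccccc34)(c3ccccc3)C2=O)cc1` gives 91.9 nM

Compound 3 holds the highest of the three numbers, yet both gaps are within scatter: a 1.2-fold higher number from compound 1 to compound 3 (0.09 log units; within the scatter) and a 1.7-fold higher number from compound 2 to compound 3 (0.23 log units; within the scatter). Compound 4 `O=C(NO)c1ccc(CN2C(=O)NC(Cc3ccc4ccccc4c3)(c3ccccc3)C2=O)cc1` is the unmeasured regioisomer, differing by naphthalen-2-yl in place of naphthalen-1-yl on a saturated chain carbon bound to a saturated ring carbon. Among the measured compounds shown here, no measured step covers this change; the steps that bear on it are the other changes at the same place, a 1.4-fold lower number from compound 1 to compound 2 (0.14 log units; within the scatter), a 1.2-fold higher number from compound 1 to compound 3 (0.09 log units; within the scatter) and a 1.7-fold higher number from compound 2 to compound 3 (0.23 log units; within the scatter), all within scatter. In this assay compound 4 is therefore expected to show no step beyond scatter, a 1.1-fold lower number from compound 3 to compound 4 (0.06 log units; within the scatter). The estimate for compound 4 in this assay is 80 nM, with a range from 35 nM to 180 nM.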

Compound 4, half-maximal inhibitory concentration: 74.6 nM
Estimate against measurement, compound 4: 1.1-fold (0.03 log units) above; measured number inside the range.
By their numbers in this assay, from the lowest: compounds 2, 4, 1 and 3 (each within the scatter of the next).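

In this assay naphthalen-2-yl in place of naphthalen-1-yl on a saturated chain carbon bound to a saturated ring carbon gives a 1.2-fold lower number from compound 3 to compound 4 (0.09 log units; within the scatter) and so the naphthalene attachment point leaves no readable mark here. With a 1.4-fold higher number from compound 2 to compound 4 (0.14 log units; within the scatter) and a 1.0-fold lower number from compound 1 to compound 4 (0.00 log units; within the scatter) as well, hydrogen, 4-chlorophenyl and both naphthyl groups all fall within the scatter at this place. Nothing at hand gives a reason for this flat response.

Open, from the compounds shown here alone, is whether an amine, a carboxylic acid or a longer chain at this place would stay within the scatter or finally separate from these four compounds.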